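Amide substituent change on the carboxamide of compound 3

The compounds below may be only part of what the source reports. "The series", "measured", "known", "first", "only" and "open" are said of these compounds alone.

Of the compounds shown here, three have been measured in an in vitro assay on BaF3 cells for displacement of a labelled ligand from C-X-C chemokine receptor type 3 (Homo sapiens); on this read-out lower numbers stand for stronger inhibition and higher numbers for weaker inhibition. Compound 1 `CC[C@H]1CN(c2nc(N)c(C(N)=O)nc2Cl)CCN1C1CCN(Cc2ccc(C#N)cc2)CC1` gives 8.5 nM in this assay. Compound 2 `CC[C@H]1CN(c2nc(N)c(C(=O)NCC(C)(C)O)nc2Cl)CCN1C1CCN(Cc2ccc(Cl)cc2)CC1` gives 8.4 nM in this assay. Compound 3 `CC[C@H]1CN(c2ncc(C(=O)NC(C)(C)C)nc2Cl)CCN1C1CCN(C(=O)c2ccc(Cl)nc2N)CC1` gives 1.5 nM in this assay, the lowest of the three numbers, and its gap to compound 2 as well as to compound 1 lies beyond the usual scatter. Compound 1 and compound 2 carry a different core from compound 3 and also differ in the amide part, so their numbers are not read as a step from compound 3.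

The next compound, compound 4 `CC[C@H]1CN(c2ncc(C(=O)NCCO)nc2Cl)CCN1C1CCN(C(=O)c2ccc(Cl)nc2N)CC1`, keeps the core and the piperidine amide of compound 3 and alters the carboxamide only: 2-hydroxyethyl in place of tert-butyl on an amide-type nitrogen. Among the measured compounds shown here, no measured pair in the set isolates this change, so no step size is known for it. Since compound 3 stands at 1.5 nM, the expectation is a small move towards a higher number in this assay, of a size that may not exceed the scatter. The estimated step from compound 3 to compound 4 is a 2.3-fold higher number from compound 3 to compound 4 (0.37 log units; beyond the scatter). Compound 4 is accordingly expected to give about 3.5 nM in this assay, with a range from 1.2 nM to 12 nM.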

Compound 4, half-maximal inhibitory concentration: 2.9 nM
For compound 4 the middle estimate is 1.2-fold (0.08 log units) above the measured one; the measured number falls inside the stated range.
By their numbers in this assay, from the lowest: compounds 3 and 4 (each within the scatter of the next); then compounds 2 and 1 (each within the scatter of the next).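

In this assay, among the compounds shown here, the carboxamide substituent can now be read on its own for the first time: a 1.9-fold higher number from compound 3 to compound 4 (0.29 log units; within the scatter), so compound 3 and compound 4 cannot be told apart on this read-out. At this amide-type nitrogen, the series therefore accepts 2-hydroxyethyl in place of tert-butyl without a readable cost, even though the exchange swaps an all-carbon group of 4 heavy atoms for one of 3 heavy atoms carrying 1 hydrogen-bond donor and 1 hydrogen-bond acceptor. Nothing at hand accounts for this result.

For the compounds shown here, the single step cannot separate the loss of the branched tert-butyl from the arrival of the hydroxyl, so an unbranched ethyl group, a 2-methoxyethyl group, or a longer chain such as 3-hydroxypropyl would be needed to tell the two apart, and how far the position extends to an amine or a carboxylic acid at the chain end stays open. Steps to compound 1 and compound 2 cannot be read, so it also remains open whether the same exchange behaves alike on their cores and piperidine substituents.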